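The source may hold more compounds than are shown below. What is called first, only, known or untested is meant among the compounds shown, and "the series" means these compounds.

Measured so far in a functional assay on MCF7 cells (Homo sapiens) for antiproliferative activity, with a stated time of 96 h; a higher number here means a weaker inhibitor, a lower number a stronger inhibitor:

- compound 1 `Cc1cc(=O)oc2cc(OCC(=O)c3ccc4ccccc4c3)ccc12`: > 100000 nM, a limit and not a number
- compound 2 `Cc1cc(=O)oc2cc(OCC(=O)c3ccc4c(c3)OCCCO4)ccc12`: > 100000 nM, a limit and not a number
- compound 3 `COc1ccc(C(=O)COc2ccc3c(C(F)(F)F)cc(=O)oc3c2)cc1`: "not active" (no number reported)

Compound 3 has no number to place on a scale, only the verbal result shown above. The other two entries give no exact figure either, and the only numerical reference is the limit of > 100000 nM in this assay, at which 2 of the 3 values shown sit.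

The next compound is compound 4 `Cc1ccc(C(=O)COc2ccc3c(C(F)(F)F)cc(=O)oc3c2)cc1`, which differs from compound 3 in one place: methyl in place of methoxy on an aromatic carbon. Seen one bond further out, 4-methoxyphenyl becomes 4-methylphenyl, and the change sits para to a large group.

Among the measured compounds shown here, no pair of measured compounds shows what this swap does, so any forecast must remain cautious. The starting point is compound 3, reported as "not active" (no number reported). From there, no step beyond the scatter is expected in this assay, and no direction can be favoured. Compound 4 is expected to remain without measurable activity and may well be reported only as a limit.

If a number is obtained, the estimate for compound 4 is 100000 nM, with an expected range of 30000 nM to 200000 nM.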

Compound 4, half-maximal inhibitory concentration: "not active" (no number reported)
Nothing numeric was reported for compound 4; the estimate stays without a comparison.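

Compound 3 and compound 4 are both reported as "not active" in this assay, without a number, so no step can be read from replacing methoxy with methyl. These compounds leave open whether this swap changes activity at all, since the only numerical reference is a limit and not an exact value: the limit of > 100000 nM in this assay, at which 2 of the 4 values shown sit.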